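The source may hold more compounds than are shown below. What is called first, only, known or untested is meant among the compounds shown, and "the series" means these compounds.

In a functional assay on PC-3 cells (Homo sapiens) for antiproliferative activity, read by MTT assay (on this read-out higher numbers stand for weaker inhibition and lower numbers for stronger inhibition), compound 3 `Cn1c(=O)c(=O)n(C2CCCC2)c2nc(N/N=C/c3ccc(F)cc3Cl)ncc21` gives 15200 nM. Compound 2 `Cn1c(=O)c(=O)n(C2CCCC2)c2nc(N/N=C/c3ccc(F)c(Cl)c3)ncc21` gives 8550 nM, and the step of a 1.8-fold higher number from compound 2 to compound 3 (0.25 log units; within the scatter) lies within the scatter, so the two stand together. Compound 1 `Cn1c(=O)c(=O)n(C2CCCC2)c2nc(N/N=C/c3ccc(O)cc3)ncc21` gives > 100000 nM, which is a limit of the assay and not a number. Compound 4 `Cn1c(=O)c(=O)n(C2CCCC2)c2nc(N/N=C/c3cccc([N+](=O)[O-])c3)ncc21` is not yet measured; it differs from compound 3 in 3-nitrophenyl in place of 2-chloro-4-fluorophenyl on a carbon with a double bond to nitrogen.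

Of the measured steps, an at least 6.5-fold lower number from compound 1 to compound 3 (0.81 log units; beyond the scatter) and an at least 11-fold lower number from compound 1 to compound 2 (1.06 log units; beyond the scatter) both replace a 4-hydroxyphenyl with a halogenated phenyl and are beyond the scatter, while a 1.8-fold higher number from compound 2 to compound 3 (0.25 log units; within the scatter) only moves the chlorine and stays within it. Among the measured compounds shown here, none of them exchanges a halogenated phenyl for a nitrophenyl, so no measured step matches the present change directly. The one caution is the limit of > 100000 nM in this assay, at which 1 of the 3 values shown sits, reached by compound 1 alone. For compound 4 the expected step is a 1.3-fold lower number from compound 3 to compound 4 (0.10 log units; within the scatter), that is, no change beyond the scatter is assumed. Compound 4 is therefore estimated at 12000 nM, with a range from 3000 nM to 50000 nM.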

Compound 4, half-maximal inhibitory concentration: 20300 nM
The estimate for compound 4 lay 1.7-fold (0.23 log units) below the measured number; measured number inside the range.
By their numbers in this assay, from the lowest: compounds 2, 3 and 4 (each within the scatter of the next, the first and the last beyond it). At a limit, above all of these: compound 1.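

In this assay, the halogens are not needed for a measurable number at this position: a 1.3-fold higher number from compound 3 to compound 4 (0.13 log units; within the scatter), so 3-nitrophenyl and 2-chloro-4-fluorophenyl stand together. The same replacement is not neutral against the other chlorofluorophenyl, since a 2.4-fold higher number from compound 2 to compound 4 (0.38 log units; beyond the scatter), so the two halogenated rings, themselves within the scatter of each other, do not relate to 3-nitrophenyl in the same way. Against the hydroxyphenyl, a halogen-free ring also reads clearly better, with an at least 4.9-fold lower number from compound 1 to compound 4 (0.69 log units; beyond the scatter), though the value of compound 1 is a limit and not a number: the limit of > 100000 nM in this assay, at which 1 of the 4 values shown sits.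

The compounds shown leave open how an unsubstituted phenyl, an aminophenyl or a carboxyphenyl would read at this place. On these data alone, whether the nitro group depends on its ring position also stays open, as 4-nitrophenyl is not among them.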